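This account rests on a few compounds, and the source may have more. Where it says the series, first, only, none or still open, it means among the compounds named here.

Measured in a physicochemical assay for solubility, in phosphate buffer, at pH 7.4; on this read-out higher numbers stand for higher solubility and lower numbers for lower solubility:
- Compound 1 `CCOC(=O)c1c(-c2ccccc2Cl)[nH]c2cc(OC)ccc2c1=O`: 28000 nM
- Compound 2 `CCOC(=O)c1c(-c2ccc(Cl)c(Cl)c2)[nH]c2cc(OC)ccc2c1=O`: 17000 nM
- Compound 3 `CCOC(=O)c1c(-c2cccs2)[nH]c2cc(OC)ccc2c1=O`: > 100000 nM (a limit)

Compound 3 stands at a limit of the assay, not at a number: > 100000 nM.

Compound 4 `CCOC(=O)c1c(-c2ccc(OC)cc2)[nH]c2cc(OC)ccc2c1=O` has 4-methoxyphenyl in place of thiophen-2-yl on an aromatic carbon.

Two measured steps run the opposite way, putting thiophen-2-yl in place of a substituted phenyl: an at least 3.5-fold higher number from compound 1 to compound 3 (0.55 log units; beyond the scatter) and an at least 5.8-fold higher number from compound 2 to compound 3 (0.76 log units; beyond the scatter). Both lie beyond the scatter. Exchanging one phenyl group for the other gave a 1.6-fold lower number from compound 1 to compound 2 (0.22 log units; within the scatter), which lies within it.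

A drop beyond the scatter is therefore expected in this assay, with its true size left open by the limit. The expected change is an at least 4.0-fold lower number from compound 3 to compound 4 (0.60 log units; beyond the scatter). The estimate for compound 4 is 25000 nM, with an expected range from 8000 nM to 80000 nM.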

Compound 4, solubility: 8000 nM
Beside the measured number, compound 4's estimate is 3.1-fold (0.49 log units) above it; the range from low to high includes it.
By their numbers in this assay, from the lowest: compound 4; then compounds 2 and 1 (each within the scatter of the next). At a limit, above all of these: compound 3.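

In this assay, for the compounds shown here, 4-methoxyphenyl at this position gives the lowest number so far, with a 3.5-fold lower number from compound 1 to compound 4 (0.54 log units; beyond the scatter) and a 2.1-fold lower number from compound 2 to compound 4 (0.33 log units; beyond the scatter). Going by these compounds alone, the two chlorophenyl compounds alone stayed within the scatter of each other, so these steps are the first to show that exchanging one substituted phenyl for another can move this read-out beyond the scatter. The step of an at least 12-fold lower number from compound 3 to compound 4 (1.09 log units; beyond the scatter) starts from a limit, so its true size stays open: the limit of > 100000 nM in this assay, at which 1 of the 4 values shown sits.

As far as these compounds go, the true value of compound 3 remains unknown. Also open, from the compounds shown here alone, is how a phenyl carrying an amine or a carboxylic acid would read at this position.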